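Moving the thiophene attachment on an aminothiophene ketone

The source may hold more compounds than are shown below. What is called first, only, known or untested is meant among the compounds shown, and "the series" means these compounds.

Measured compounds:
compound 1 `COc1cccc(-c2sc(N)c(C(=O)c3ccc(Cl)cc3)c2CC(C)(C)C)c1`: 1%
compound 2 `CC(C)(C)Cc1c(-c2cccs2)sc(N)c1C(=O)c1ccc(Cl)cc1`: 1%

In an assay on CHO cells for displacement of a labelled ligand from adenosine receptor A3 (Homo sapiens), read by scintillation counting, tested at 10 uM (a higher number here means more inhibition at the concentration tested (going by the name of the read-out), a lower number less inhibition), compound 1 gives 1%. Compound 2 carries a thiophen-2-yl in place of the 3-methoxyphenyl of compound 1, and in this assay compound 2 gives 1%. The step of no change at the digits printed from compound 1 to compound 2 (within the scatter) shows that exchanging one aromatic substituent for another at this position of the shared core left the read-out where it was. Among the compounds with values here, compound 2 therefore stands level with compound 1 on the numbers so far; neither shows any inhibition worth noting in this assay.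

Compound 3 `CC(C)(C)Cc1c(-c2ccsc2)sc(N)c1C(=O)c1ccc(Cl)cc1` is the next compound in this series. Its difference from compound 2 is thiophen-3-yl in place of thiophen-2-yl on an aromatic carbon. Within the data shown here, the only step available, from compound 1 to compound 2, replaced a whole aryl group without effect, and the move from compound 2 to compound 3 keeps the same atoms and changes only how the thiophene is joined. The step from compound 2 to compound 3 is therefore expected to be a number 1 percentage points higher from compound 2 to compound 3 (within the scatter), that is, nothing beyond the scatter. For compound 3 the estimate in this assay is 2%, with a range from 0% to 12%.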

Compound 3, a percentage reported as inhibition, at one concentration (the size of the read-out at that concentration, not a potency): 4%
Beside the measured number, compound 3's estimate is 2 percentage points below it, within the range that was stated.
By their numbers in this assay, from the lowest: compounds 1, 2 and 3 (each within the scatter of the next).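

In this assay, joining the thiophene through its other ring carbon, with the same atoms, gives a number 3 percentage points higher from compound 2 to compound 3 (within the scatter), so the way this ring is attached, on the aromatic carbon next to the ring sulfur, does not separate these two compounds. Set against the 3-methoxyphenyl group, thiophen-3-yl gives a number 3 percentage points higher from compound 1 to compound 3 (within the scatter), which extends to a second thiophene isomer what the earlier pair had shown only for thiophen-2-yl: in these compounds, exchanging one of these aromatic groups for another at this position leaves the read-out within the scatter. Nothing measured for these compounds offers an explanation for this result.

All three compounds carry an aromatic ring at this position, so the data leave open whether a non-aromatic group there, such as an aminomethyl group, a carboxylic acid or a longer alkyl chain, would give a read-out beyond the scatter. They also leave open whether changing the neopentyl group or the amino group of the shared core, rather than this aromatic substituent, would move the read-out in this assay.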